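A few compounds are considered here, and "the series" means these few. Any claim that something is new, unique, unknown or untested is made for them only; others in the source may bear on it.

Of the compounds shown here, two have been measured so far in a functional assay on MKN-45 cells (Homo sapiens) for inhibition, with a stated time of 72 h; a lower number here means a stronger inhibitor, a higher number a weaker inhibitor. Compound 1 `COc1cc(C(=O)c2ccc3c(ccn3C)c2)cc(OC)c1OC` gives 11.2 nM, and compound 2 `COc1cc(C(=O)c2ccc3c(ccn3C(C)C)c2)cc(OC)c1OC` gives 470 nM, the higher of the two numbers. Compound 3 `COc1cc(C(=O)c2ccc3c(ccn3CO)c2)cc(OC)c1OC` has not yet been measured. It carries hydroxymethyl in place of isopropyl on an aromatic nitrogen. Among the measured compounds shown here, one measured step bears on this place: a 42-fold higher number from compound 1 to compound 2 (1.62 log units; beyond the scatter), a large step beyond the scatter, with isopropyl in place of methyl on the same aromatic nitrogen. For the measured compounds named here, no measured compound has a hydrogen-bond donor there, so the data do not test that feature. With isopropyl leaving, a move to a lower number in this assay is expected, recovering part but probably not all of that step. The expected change is a 7.8-fold lower number from compound 2 to compound 3 (0.89 log units; beyond the scatter). Compound 3 is estimated at 60 nM, with a range of 15 nM to 300 nM.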

Compound 3, half-maximal inhibitory concentration: 33 nM
Estimate against measurement, compound 3: 1.8-fold (0.26 log units) above, within the range that was stated.
By their numbers in this assay, from the lowest: compound 1; then compound 3; then compound 2.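

In this assay, hydroxymethyl, the only group shown on this aromatic nitrogen with a hydrogen-bond donor and acceptor, gives a 14-fold lower number from compound 2 to compound 3 (1.15 log units; beyond the scatter) and so recovers most of the loss seen with isopropyl. The recovery is incomplete, with a 2.9-fold higher number from compound 1 to compound 3 (0.47 log units; beyond the scatter) as a modest step that leaves methyl with the lowest number of the three compounds. (Nothing measured here accounts for either step).

Ethyl, which would sit on this nitrogen without the hydroxy, and methoxymethyl, which would keep the oxygen without the hydrogen-bond donor, would be needed to separate the effect of the hydroxy from that of the chain itself. Going by these compounds, how a longer chain, such as hydroxyethyl, or an amine on the chain would read in this assay remains open.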